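The compounds below may be only part of what the source reports. "The series", "measured", "known", "first", "only" and "open" are said of these compounds alone.

Compound 1 `Cn1cc(/C=C2/C(=O)Nc3ccccc32)c2cc(Nc3nccc(-c4ccccc4)n3)ccc21` carries an unsubstituted phenyl ring on the shared core, and in a functional assay on U-87MG ATCC cells (Homo sapiens) for cytotoxicity, read by MTT assay, with a stated time of 48 h (on this read-out higher numbers stand for weaker inhibition and lower numbers for stronger inhibition), compound 1 gives 14100 nM. Compound 2 `Cc1ccc(-c2ccnc(Nc3ccc4c(c3)c(/C=C3/C(=O)Nc5ccccc53)cn4C)n2)cc1` places a methyl on that ring. In this assay compound 2 reaches only a limit, > 100000 nM. The step of an at least 7.0-fold higher number from compound 1 to compound 2 (0.85 log units; beyond the scatter) is thus known only as a lower bound because compound 2 sits at the limit of > 100000 nM in this assay, at which 1 of the 2 values shown sits, so where compound 2 truly stands on the numbers cannot be said beyond that bound.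

Compound 3 `COc1ccc(-c2ccnc(Nc3ccc4c(c3)c(/C=C3/C(=O)Nc5ccccc53)cn4C)n2)cc1` differs from compound 2 by methoxy in place of methyl on an aromatic carbon. For the measured compounds named here, the only measured step that touches this ring is the one from compound 1 to compound 2, which was at least modest and ran toward weaker inhibition; no measured pair here swaps methyl for methoxy, so the size of that exchange is untested. Compound 3 is expected to remain weak, close to the limit at which compound 2 sits, with an estimated value of 70000 nM and a range from 20000 nM to 250000 nM. This estimate for compound 3 corresponds to a step of an at least 1.4-fold lower number from compound 2 to compound 3 (0.15 log units; that floor lies within the scatter), an expectation rather than a measurement.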

Compound 3, half-maximal inhibitory concentration: > 100000 nM
Compound 3: a limit, no number (the forecaster's own chance of this, stated with the estimate: 50%); middle value at least 1.4-fold (0.15 log units) away from the limit.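

In this assay the change from hydrogen to methoxy on this aromatic carbon, para to a large group, gives an at least 7.0-fold higher number from compound 1 to compound 3 (0.85 log units; beyond the scatter), so the loss seen with methyl is not confined to that one group: both substituents tried here leave the compound on the weak side of the unsubstituted phenyl ring of compound 1. Compound 3 gives > 100000 nM, which is a limit and not a number. Whether 4-methylphenyl and 4-methoxyphenyl differ at all cannot be read, because both compounds lie beyond the range of the assay: the limit of > 100000 nM in this assay, at which 2 of the 3 values shown sit.

As far as these compounds go, how far compound 2 and compound 3 truly lie from compound 1 remains open, as does the question of whether the oxygen in methoxy matters at all in this assay. Also open, from the compounds shown here alone, is whether any group at this place keeps a readable value, for example a fluorine, a hydroxyl, an amine or a carboxylic acid, and whether a methyl or methoxy on another carbon of this ring would behave in the same way.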